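A few compounds are considered here, and "the series" means these few. Any claim that something is new, unique, unknown or untested is made for them only; others in the source may bear on it.

Compound 3 `CC(C)Cc1ccc(C(C)c2nnc3sc(-c4ccc(Br)cc4)nn23)cc1` reads 67% in a functional assay on the whole organism (strain Wistar albino) for inhibition, with Rattus norvegicus as the target, read by paw edema, with stated times of 30 min and 3 h, at a dose of 20 mg/kg by the oral route; on this read-out lower numbers stand for less inhibition and higher numbers for more inhibition at the one dose given (going by the name of the read-out). Among the three compounds measured it gives the highest number, but its nearest neighbour, compound 1 `Cc1nn2c(C(C)c3ccc(CC(C)C)cc3)nnc2s1` with 62%, lies within the scatter of it, so the two cannot be ranked against each other; only compound 2 `CCCc1nn2c(C(C)c3ccc(CC(C)C)cc3)nnc2s1` with 34% sits clearly apart. Compound 4 `CC(C)Cc1ccc(C(C)c2nnc3sc(-c4ccco4)nn23)cc1` differs from compound 3 at the position where the ring substituent sits on the shared core: furan-2-yl in place of 4-bromophenyl on an aromatic carbon.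

Two measured steps end at that same place. The step of a number 5 percentage points higher from compound 1 to compound 3 (within the scatter) shows that replacing methyl by 4-bromophenyl changed little, while the step of a number 33 percentage points higher from compound 2 to compound 3 (beyond the scatter) shows that replacing propyl by 4-bromophenyl raised the number clearly. Within the data shown here, both leave open how one aromatic ring compares with another at this position, since no such pair has been measured. With an aromatic ring again in place, a step close to none beyond the scatter is expected, put at a number 7 percentage points lower from compound 3 to compound 4 (within the scatter). Compound 4 is therefore estimated to give 60%, within a range of 45% to 72%.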

Compound 4, a percentage reported as inhibition, in the whole organism at one dose (the size of the read-out at that dose, not a potency): 64%
The estimate for compound 4 lay 4 percentage points below the measured number; low and high end bracket the measured number.
By their numbers in this assay, from the lowest: compound 2; then compounds 1, 4 and 3 (each within the scatter of the next).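

Exchanging one aromatic ring for another at this position, a swap not seen before, gives a number 3 percentage points lower from compound 3 to compound 4 (within the scatter) and so does not separate furan-2-yl from 4-bromophenyl, even though one is a five-membered ring with a hetero atom and the other a six-membered ring of carbon only. The furan-2-yl group also gives a number 30 percentage points higher from compound 2 to compound 4 (beyond the scatter) and a number 2 percentage points higher from compound 1 to compound 4 (within the scatter) so it repeats what 4-bromophenyl showed: both rings stand clear of propyl but not of methyl, and compound 1 therefore goes against any idea that an aromatic ring is needed here. No evidence at hand explains these readings.

Going by these compounds, whether unsubstituted phenyl or a ring carrying an amine or a carboxylic acid would read like these two rings stays open. So does the effect of ethyl or of a chain longer than propyl at this position, which would show whether the low reading of compound 2 belongs to chains in general.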